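A halogen swap with almost no numbers to guide it

A few compounds are considered here, and "the series" means these few. Any claim that something is new, unique, unknown or untested is made for them only; others in the source may bear on it.

Compound 1 (`OC[C@H]1O[C@@H](n2cnc3c(NCc4cccc(F)c4)ncnc32)[C@H](O)[C@@H]1O`), compound 2 (`OC[C@H]1O[C@@H](n2cnc3c(NCc4ccc(Cl)cc4)ncnc32)[C@H](O)[C@@H]1O`), compound 3 (`COc1cccc(CNc2ncnc3c2ncn3[C@@H]2O[C@H](CO)[C@@H](O)[C@H]2O)c1OC`) and compound 4 (`OC[C@H]1O[C@@H](n2cnc3c(NCc4ccc(F)cc4Cl)ncnc32)[C@H](O)[C@@H]1O`) share one core. In a functional assay on B16 cells (Mus musculus) for antiproliferative activity, with a stated time of 72 h (a lower number here means a stronger inhibitor, a higher number a weaker inhibitor), compound 3 stands without a number, recorded as "not determined" (no result reported). Compound 1 has no number either, recorded as "not determined" (no result reported). Compound 2 gives > 166000 nM, which is a limit and not a number. The change 2-chloro-4-fluorophenyl in place of 2,3-dimethoxyphenyl on a saturated chain carbon bound to a nitrogen on an aromatic ring puts 2-chloro-4-fluorophenyl in place of 2,3-dimethoxyphenyl on a saturated chain carbon bound to a nitrogen on an aromatic ring. Going by the values given here, no measured step gives the size of this change, so the only guide is compound 2, with the limit of > 166000 nM in this assay, at which 1 of the 3 values shown sits. Compound 4 is therefore expected to stay a weak inhibitor in this assay, with only a small step, if any, towards stronger inhibition. Compound 4 is expected near 100000 nM, with an estimated range from 15000 nM to 250000 nM.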

Compound 4, half-maximal inhibitory concentration: > 166000 nM
Compound 4: only a limit was reported (the forecaster's own chance of this, stated with the estimate: 60%); middle value at least 1.6-fold (0.22 log units) from the limit.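

Compound 2 and compound 4 each give only a limit in this assay, so no step can be read between them. The compounds shown leave open whether any group at this place on the shared core brings a readable potency in this assay.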